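The compounds below may be only part of what the source reports. "The series", "measured", "known", "first", "only" and "open" are said of these compounds alone.

Measured in a functional assay on HeLa cells (Homo sapiens) for inhibition, read by MTT assay, with a stated time of 48 h; a lower number here means a stronger inhibitor, a higher number a weaker inhibitor:
- compound 1 `CCc1ccc(-c2nc3ccccn3c2Sc2ccccc2)cc1`: 52100 nM
- compound 2 `c1ccc(Sc2c(-c3cccc4ccccc34)nc3ccccn23)cc1`: 33100 nM
- compound 3 `CS(=O)(=O)c1ccc(-c2nc3ccccn3c2Sc2cccc3ccccc23)cc1`: 34600 nM

Compound 1 stands within the usual scatter of both other compounds, so this assay cannot separate these three. The next compound, compound 4 `c1ccc(Sc2c(-c3cccs3)nc3ccccn23)cc1`, has thiophen-2-yl in place of 4-ethylphenyl on an aromatic carbon. For the measured compounds named here, no measured pair differs in one place only, so nothing here directly sizes this change. The three values share one narrow range, which gives no reason to expect a large shift. The expected change, a 1.2-fold lower number from compound 1 to compound 4 (0.06 log units; within the scatter), stays within the scatter, in neither direction. For compound 4 the estimated value is 45000 nM, with an expected range of 20000 nM to 100000 nM.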

Compound 4, half-maximal inhibitory concentration: 19900 nM
Estimate against measurement, compound 4: 2.3-fold (0.35 log units) above, and the stated range ends above it.
By their numbers in this assay, from the lowest: compounds 4, 2, 3 and 1 (each within the scatter of the next, the first and the last beyond it).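

For the compounds shown here, exchanging 4-ethylphenyl for thiophen-2-yl on this aromatic carbon gives a 2.6-fold lower number from compound 1 to compound 4 (0.42 log units; beyond the scatter) in this assay, the first single-place change that can be sized here. This position therefore responds to the group it carries, although the step is modest and rests on a single pair. Nothing available explains the step.

This one step changes both the ring and the ethyl group, so their shares cannot be separated. An unsubstituted phenyl or a furan-2-yl at this position would help to tell them apart.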